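The source may report more compounds than this note shows. Statements on the series, on what has been measured and on what is new or still open speak of the compounds shown alone.

Compound 1 `COc1cc(-c2cc(/C=C/C(=O)c3ccc(N)cc3)[nH]n2)cc(OC)c1OC` is tested in a functional assay on NCI-H460 cells (Homo sapiens) for inhibition, read by sulforhodamine B assay, with a stated time of 48 h (on this read-out lower numbers stand for higher toxicity in this test and higher numbers for lower toxicity in this test), where compound 1 gives 44800 nM. Compound 2 `COc1ccc(-c2cc(/C=C/C(=O)c3ccc(OC)c(OC)c3)[nH]n2)cc1` gives 22800 nM in this assay, and the two numbers lie within the usual scatter of each other, so neither can be called the more or the less toxic. Compound 3 `COc1cc(-c2cc(/C=C/C(=O)c3ccc(Cl)c(Cl)c3)[nH]n2)cc(OC)c1OC` reaches only the limit of this assay, > 100000 nM, which is not a number. Within the data shown here, the step of an at least 2.2-fold higher number from compound 1 to compound 3 (0.34 log units; beyond the scatter) is the only single change among the measured compounds, and its size is known only as a lower bound because of the limit of > 100000 nM in this assay, at which 1 of the 3 values shown sits.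

Compound 4 `COc1ccc(-c2cc(/C=C/C(=O)c3ccc(N)cc3)[nH]n2)cc1OC` differs from compound 1 by hydrogen in place of methoxy on an aromatic carbon. Among the measured compounds shown here, the one measured step concerns the ring on the carbonyl carbon, not the ring where this change sits, so no measured step bears on it directly. Compound 2 differs from compound 1 in two places, so its value gives no clean reading either. The expectation is therefore a step of no more than the scatter, a 1.0-fold higher number from compound 1 to compound 4 (0.00 log units; within the scatter), and compound 4 is estimated at 45000 nM, between 20000 nM and 100000 nM.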

Compound 4, concentration lethal to 50% of the cells: 10600 nM
For compound 4 the middle estimate is 4.2-fold (0.63 log units) above the measured one; the measured number lies below the stated range.
By their numbers in this assay, from the lowest: compound 4; then compounds 2 and 1 (each within the scatter of the next). At a limit, above all of these: compound 3.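

In this assay, hydrogen in place of methoxy on this aromatic carbon gives a 4.2-fold lower number from compound 1 to compound 4 (0.63 log units; beyond the scatter), which means higher toxicity in this test. The ring carrying the methoxy groups therefore matters as well as the ring on the carbonyl carbon, the only place where a single change had been read before. Nothing shown gives a reason for this drop in the number.

Going by these compounds, it remains open whether only the absence of a group at this place matters, or whether a hydroxyl, a fluorine or an ethoxy group there would give a similar number. On these data alone, it also remains open whether the same step would appear with a 3,4-dichlorophenyl in place of the 4-aminophenyl on the carbonyl carbon.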